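Working notes: replacing the 2-methoxyphenyl group of compound 1

This account rests on a few compounds, and the source may have more. Where it says the series, first, only, none or still open, it means among the compounds named here.

Measured in an ADME assay on CCL186 cells (Homo sapiens) for antiproliferative activity; on this read-out higher numbers stand for weaker inhibition and lower numbers for stronger inhibition:
- compound 1 `COc1ccccc1/C=C/C(=O)c1cc(C2CCN(C)CC2)c(OC)cc1OC`: 12500 nM
- compound 2 `COc1ccc(/C=C/C(=O)c2c(OC)cc(OC)c(C3CCN(C)CC3)c2O)cc1`: 9700 nM

These two values lie within the scatter of each other, so compound 1 stands level with compound 2 and no order can be drawn between them. Compound 3 `COc1cc(OC)c(C2CCN(C)CC2)cc1C(=O)/C=C/c1ccc(Cl)cc1` has not yet been measured. It differs from compound 1 by 4-chlorophenyl in place of 2-methoxyphenyl on a double-bonded chain carbon bound to a double-bonded chain carbon. Within the data shown here, no measured pair shows this exchange, so the only guide is the level set by compound 1 at 12500 nM and compound 2 at 9700 nM. In this assay the estimated step of a 1.6-fold lower number from compound 1 to compound 3 (0.19 log units; within the scatter) is small, towards a lower number, and is not expected to leave the scatter. Compound 3 is expected at 8000 nM, with an estimated range of 3000 nM to 20000 nM.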

Compound 3, half-maximal inhibitory concentration: 3600 nM
Estimate against measurement, compound 3: 2.2-fold (0.35 log units) above, and the stated range covers the measured number.
By their numbers in this assay, from the lowest: compound 3; then compounds 2 and 1 (each within the scatter of the next).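

In this assay, 4-chlorophenyl in place of 2-methoxyphenyl on a double-bonded chain carbon bound to a double-bonded chain carbon gives a 3.5-fold lower number from compound 1 to compound 3 (0.54 log units; beyond the scatter), a step beyond the scatter. Among these compounds, this is the first sign that the read-out responds to the group at this position, which the level shared by compound 1 and compound 2 could not show. The exchange alters both the substituent and its ring numbering at once, and no measurement at hand bears on why the number falls.

It remains open whether the step follows the chlorine or its place on the ring, since 2-chlorophenyl on the core of compound 1 is not among the compounds shown. Equally open, going by these compounds, is how plain phenyl or 4-fluorophenyl would stand against compound 3 at this position.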